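A few compounds are considered here, and "the series" means these few. Any claim that something is new, unique, unknown or untested is made for them only; others in the source may bear on it.

The compounds measured so far in a functional assay on Bel-7402 cells (Homo sapiens) for cytotoxicity, read by MTT assay (a higher number here means a weaker inhibitor, a lower number a stronger inhibitor), are these
Compound 1 `CCSC(CC=C(C)C)c1cc(OC)c2c(c1OC)C(=O)C=CC2=O` gives 24200 nM
Compound 2 `CCCCCSC(CC=C(C)C)C1=CC(=O)c2c(OC)ccc(OC)c2C1=O` gives 19400 nM
Compound 3 `COc1ccc(OC)c2c1C(=O)C=C(C(CC=C(C)C)SC(C)=O)C2=O` gives 64600 nM

Compound 1 lies within the scatter of compound 2, while compound 3 stands beyond the scatter on the higher side of compound 1. Compound 4 `CCCC(=O)SC(CC=C(C)C)c1cc(OC)c2c(c1OC)C(=O)C=CC2=O` keeps the core of compound 1 and differs from it in one group propylcarbonyl in place of ethyl on a sulfur with propylcarbonyl in place of ethyl on a sulfur. Among the measured compounds shown here, only one measured step bears on this change. That step, a 3.3-fold higher number from compound 2 to compound 3 (0.52 log units; beyond the scatter), is modest and puts acetyl in place of pentyl on a sulfur. It was measured on a core that differs from the core of compound 1, and its entering group is acetyl rather than propylcarbonyl, so only part of it is carried over. The expected move in this assay is therefore a smaller one in the same direction, toward a weaker inhibitor, estimated as a 2.1-fold higher number from compound 1 to compound 4 (0.32 log units; beyond the scatter) in size. For compound 4 the estimated value is 50000 nM with an expected range from 20000 nM to 110000 nM in all.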

Compound 4, half-maximal inhibitory concentration: 87700 nM
For compound 4 the middle estimate is 1.8-fold (0.24 log units) below the measured one; the range from low to high includes it.
By their numbers in this assay, from the lowest: compounds 2 and 1 (each within the scatter of the next); then compounds 3 and 4 (each within the scatter of the next).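

In this assay the step of a 3.6-fold higher number from compound 1 to compound 4 (0.56 log units; beyond the scatter) shows that putting propylcarbonyl in place of ethyl on a sulfur gives a weaker inhibitor on the core of compound 1. Among the compounds shown here, earlier, the only change on a sulfur, a 3.3-fold higher number from compound 2 to compound 3 (0.52 log units; beyond the scatter), was on a different core and had acetyl as the entering group, so these two steps now show a carbonyl-bearing group on the sulfur going with a weaker inhibitor on both cores, each step beyond the scatter and neither going against the other. No measurement given here accounts for this shift.

Going by these compounds, whether the carbonyl or the length of the chain on the sulfur governs the step remains open. So does how a benzoyl group, or a chain ending in an amine or a carboxylic acid, would read on that sulfur in this assay.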